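Chain branching in a prostaglandin-type agonist pair

The source may hold more compounds than are shown below. What is called first, only, known or untested is meant among the compounds shown, and "the series" means these compounds.

Measured compounds:
Compound 1, `CCCCC1([C@H](O)/C=C/[C@H]2COC(=O)N2CCSc2nc(C(=O)O)cs2)CCC1`: 3.9 nM
Compound 2, `CCCCC(C)(C)[C@H](O)/C=C/[C@H]1CCC(=O)N1CCSc1nc(C(=O)O)cs1`: 8.4 nM

In an assay on isolated protein for agonist activity at prostaglandin E2 receptor EP3 subtype (Homo sapiens) (a higher number here means that more compound is needed for the effect, a lower number that less compound is needed), compound 1 gives 3.9 nM, the lower of the two numbers recorded. In this assay compound 2 gives 8.4 nM, a higher number by a margin beyond the scatter. Within the data shown here, no pair of measured compounds differs in a single place, so no isolated step is available.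

Compound 3, `CC(C)(C)CCC1([C@H](O)/C=C/[C@H]2COC(=O)N2CCSc2nc(C(=O)O)cs2)CCC1`, differs from compound 1 by tert-butyl in place of ethyl on a saturated chain carbon, two bonds along the chain from a saturated ring carbon. Nothing measured tests this change directly; a modest step toward a higher number is expected, possibly none beyond the scatter. Compound 3 is expected to give 6 nM, in the range 1.5 nM to 25 nM. The expected step is a 1.5-fold higher number from compound 1 to compound 3 (0.19 log units; within the scatter).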

Compound 3, half-maximal effective concentration: 6.7 nM
Beside the measured number, compound 3's estimate is 1.1-fold (0.05 log units) below it; measured number inside the range.
By their numbers in this assay, from the lowest: compounds 1, 3 and 2 (each within the scatter of the next, the first and the last beyond it).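

Working from the shared core, a 1.7-fold higher number from compound 1 to compound 3 (0.24 log units; within the scatter) in this assay is the first single-place step in the series, and it concerns tert-butyl in place of ethyl on a saturated chain carbon. At this position, the chain end can therefore carry the larger branched group without a change beyond the scatter. No evidence on hand accounts for this result.

Still open, going by these compounds, is whether an amine, a hydroxyl or a phenyl at the same chain end would keep the number within the scatter. A longer straight chain also remains to be compared there.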